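Trimethoxyphenyl triazole ketones: bromo for methyl on the aryl

The source may hold more compounds than are shown below. What is called first, only, known or untested is meant among the compounds shown, and "the series" means these compounds.

Measured in a functional assay on A549 cells (Homo sapiens) for cytotoxicity, read by MTT assay, with a stated time of 48 h; a higher number here means a weaker inhibitor, a lower number a stronger inhibitor:
compound 1 `Cc1ccc(C(=O)CSc2nnc(C)n2N2C(=O)c3ccccc3C2=O)cc1`: > 200000 nM
compound 2 `CCCc1nnc(SCC(=O)c2ccc(C)cc2)n1N1C(=O)c2ccccc2C1=O`: > 200000 nM
compound 3 `COc1cc(-c2nnc(SCC(=O)c3ccc(C)cc3)n2N2C(=O)c3ccccc3C2=O)cc(OC)c1OC`: 6760 nM

Compound 1 reaches only a limit of the assay in this assay, > 200000 nM. Compound 2 likewise stops at a limit, > 200000 nM. Going by the values given here, compound 3 is the only member with a number, 6760 nM, so it stands alone at the readable end of the series. The step that the two limits leave unreadable from compound 1 to compound 2 cannot be sized because both values sit at the limit of > 200000 nM in this assay, at which 2 of the 3 values shown sit. The two steps that are readable both lead to compound 3: an at least 29-fold lower number from compound 1 to compound 3 (1.47 log units; beyond the scatter) and an at least 29-fold lower number from compound 2 to compound 3 (1.47 log units; beyond the scatter), each arising from the group on the triazole carbon.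

Compound 4 `COc1cc(-c2nnc(SCC(=O)c3ccc(Br)cc3)n2N2C(=O)c3ccccc3C2=O)cc(OC)c1OC` keeps the trimethoxyphenyl group and the shared core of compound 3 and alters only the ketone aryl: bromo in place of methyl on an aromatic carbon. Among the compounds with values here, no measured step touches this ring; every sized change so far sits on the aromatic carbon of the triazole. Nothing in the series therefore points to a shift in either direction, and the step is expected to stay within the scatter, a 1.0-fold lower number from compound 3 to compound 4 (0.02 log units; within the scatter). Compound 4 is estimated at 6500 nM in this assay, with a range from 2000 nM to 20000 nM.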

Compound 4, half-maximal inhibitory concentration: 16100 nM
The estimate for compound 4 lay 2.5-fold (0.39 log units) below the measured number, within the range that was stated.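

Working notes on the ketone aryl ring: in this assay, 4-bromophenyl in place of 4-methylphenyl gives a 2.4-fold higher number from compound 3 to compound 4 (0.38 log units; beyond the scatter), the first readable step on this ring. The earlier readable steps all changed a different position, so this pair adds a new finding: with the 3,4,5-trimethoxyphenyl group held constant, exchanging one heavy atom on an aromatic carbon para to a large group moves the number beyond the scatter, and the methyl member holds the lower number of the pair, although the step is only modest. Nothing available gives a reason for the direction or size of this step.

With only one pair on this ring, the compounds shown leave open whether other groups at the same carbon, such as chloro, methoxy, an amine or a carboxylic acid, would fall on the side of methyl or of bromo, or beyond both. Also open, from the compounds shown here alone, is whether bromo in place of methyl would produce a step of similar direction and size with a group other than 3,4,5-trimethoxyphenyl on the shared core, such as a longer chain or an unsubstituted phenyl.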